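Compound 3 and a cyclopentyl swap on the sulfonyl

This account rests on a few compounds, and the source may have more. Where it says the series, first, only, none or still open, it means among the compounds named here.

Measured in an ADME assay on microsomes from liver (Mus musculus) for metabolic stability, tested at 5 uM; a lower number here means that the compound disappears faster, a higher number that the compound lasts longer:
compound 1 `CCCCCCCCNc1ccc(C(=O)O)cc1S(N)(=O)=O` gives 0.3 h
compound 2 `CN(C)S(=O)(=O)c1cc(C(=O)O)ccc1NCCC(C)(C)C` gives > 1 h as a limit
compound 3 `O=C(O)c1ccc(NCCCCCCCC(F)(F)F)c(S(=O)(=O)N2CCCC2)c1` gives > 1 h as a limit

Compound 3 stands at the limit of > 1 h in this assay, at which 2 of the 3 values shown sit, and so has a limit, not a number. The next step leads to compound 4 `O=C(O)c1ccc(NCCCCCCCC(F)(F)F)c(S(=O)(=O)NC2CCCC2)c1` with cyclopentylamino in place of pyrrolidin-1-yl on a sulfonyl sulfur. Going by the values given here, no measured pair shows this change alone. Among the compounds with values here, the only compound here with a number rather than a limit is compound 1 (0.3 h) so the expectation stays loose. The expected step in this assay is a modest fall (an at least 1.4-fold lower number from compound 3 to compound 4 (0.15 log units; that floor lies within the scatter)) that may stay close to the scatter. Compound 4 is estimated at 0.7 h with an expected range from 0.3 h to 1.5 h in this measurement.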

Compound 4, half-life: > 1 h
Compound 4 ended at the assay's limit; the forecaster's own chance of this, stated with the estimate: 35%; middle value at least 1.4-fold (0.15 log units) away from the limit.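

Compound 3 and compound 4 both give a limit rather than a number in this assay, so no step between them can be read: the limit of > 1 h in this assay, at which 3 of the 4 values shown sit.

Going by these compounds, how long either compound actually lasts, and whether cyclopentylamino in place of pyrrolidin-1-yl changes the half-life at all, stays open.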